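A hydroxy group added to compound 3

The compounds below may be only part of what the source reports. "The series", "measured", "known", "first", "only" and "open" are said of these compounds alone.

Measured in an ADME assay on BJ cells (Homo sapiens) for cytotoxicity, with a stated time of 72 h (a lower number here means that less compound is needed, a higher number that more compound is needed for the effect), where each value is a limit of the assay and not a number:

Compound 1 `CCc1ccc(NC(=O)Nc2cc(C)nc3ccccc23)cc1`: > 25000 nM
Compound 2 `Cc1cc(NC(=O)Nc2ccc(C(F)(F)F)cc2)c2ccccc2n1`: > 25000 nM
Compound 3 `Cc1cc(NC(=O)Nc2ccc(C(=O)O)cc2)c2ccccc2n1`: > 25000 nM

Compound 3 gives > 25000 nM, which is a limit. It therefore has no readable place among the three compounds, which all share one position: the limit of > 25000 nM in this assay, at which 3 of the 3 values shown sit.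

Compound 4 `Cc1cc(NC(=O)Nc2ccc(C(=O)O)c(O)c2)c2ccccc2n1` differs from compound 3 by a single change: hydroxy in place of hydrogen on an aromatic carbon. The new hydroxy group sits ortho to a carboxy group and meta to a large group.

Among the compounds with values here, no measured step tests a hydroxy group. The closest evidence comes from changes to a group on an aromatic carbon: a step that the two limits leave unreadable from compound 1 to compound 2; a step that the two limits leave unreadable from compound 1 to compound 3; and a step that the two limits leave unreadable from compound 2 to compound 3. None of these steps has a readable size, so they give no direction for the new change. Across these three compounds, ethyl, trifluoromethyl and carboxy all leave the value at the limit in this assay, and no compound here goes against that.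

The expectation therefore rests on compound 3 with its limit of > 25000 nM and on the absence of any readable step. The expected change is a number no higher from compound 3 to compound 4 (the limit leaves the size open), with none expected beyond the usual scatter. Compound 4 is estimated at 25000 nM, with an expected range from 15000 nM to 40000 nM, and the assay will most likely report only a limit again.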

Compound 4, half-maximal effective concentration in the BJ assay: > 25000 nM
Compound 4 was reported as a limit; the forecaster's own chance of this, stated with the estimate: 90%; the middle value sits exactly at the limit.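

Like compound 3, compound 4 is reported in the BJ assay only as the limit > 25000 nM and so no step between compound 3 and compound 4 can be read from these results. The compounds shown leave open what size of change, if any, the added hydroxy group brings in the BJ assay, since all four sit at that same limit. In a physicochemical assay for solubility, at pH 7.4 (a lower number here means a less soluble compound, a higher number a more soluble compound), compound 3 gives 9300 nM and compound 4 gives 26600 nM as measured, which is a 2.9-fold higher number from compound 3 to compound 4 (0.46 log units; beyond the scatter) with the added hydroxy group.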